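Azide to triazole on the chalcone series

This account rests on a few compounds, and the source may have more. Where it says the series, first, only, none or still open, it means among the compounds named here.

Measured so far:
compound 1 `COc1cc(/C=C/C(=O)c2cccc(N=[N+]=[N-])c2)ccc1O` gives 7110 nM
compound 2 `COc1ccc(/C=C/C(=O)c2cccc(N=[N+]=[N-])c2)cc1O` gives 1960 nM
compound 3 `COc1cc(/C=C/C(=O)c2cccc(-n3cc(-c4cccc(Cl)c4)nn3)c2)ccc1O` gives 14300 nM

All three numbers come from a functional assay on RAW264.7 cells (Mus musculus) for inhibition, with a stated time of 4 days; on this read-out higher numbers stand for weaker inhibition and lower numbers for stronger inhibition. Within the data shown here, compound 2 stands lowest of the three: compound 1 sits beyond the scatter above it, and compound 3, the only member carrying a triazole ring, sits furthest above it, also beyond the scatter. Among the measured compounds shown here, no single-point step between measured compounds is available, so the effect of replacing the azide by a ring is not isolated anywhere in the set.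

The next member is compound 4 `C=C(C)c1cn(-c2cccc(C(=O)/C=C/c3ccc(OC)c(O)c3)c2)nn1`, which differs from compound 2 in one place: 4-(1-methylethenyl)-1H-1,2,3-triazol-1-yl in place of azido on an aromatic carbon.

Given that compound 3, the one triazole-bearing member, shows the highest number in the set, the expected step from compound 2 to compound 4 is toward a higher number, moderately beyond the scatter, estimated as a 2.8-fold higher number from compound 2 to compound 4 (0.45 log units; beyond the scatter). Compound 4 is therefore expected to give about 5500 nM, in a range from 1800 nM to 17000 nM.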

Compound 4, half-maximal inhibitory concentration: 7760 nM
Estimate against measurement, compound 4: 1.4-fold (0.15 log units) below; measured number inside the range.
By their numbers in this assay, from the lowest: compound 2; then compounds 1, 4 and 3 (each within the scatter of the next).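

In this assay, among these compounds, the exchange of azido for 4-(1-methylethenyl)-1H-1,2,3-triazol-1-yl on an aromatic carbon, meta to a large group, gives a 4.0-fold higher number from compound 2 to compound 4 (0.60 log units; beyond the scatter) and provides the first reading of this change in one place. The step lies beyond the scatter, so on the core of compound 2 this triazole does not preserve the inhibition seen with azido. No measurement shown accounts for the step, and its cause remains unassigned.

Open, as far as these compounds go, is whether a triazole carrying an amine or a carboxylic acid in place of the 1-methylethenyl group would move the number in the same direction. Also open is the size of the same exchange on the core of compound 1, where the compounds shown offer no matching pair.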